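The source may hold more compounds than are shown below. What is called first, only, known or untested is meant among the compounds shown, and "the series" means these compounds.

Working notes on the series. In a functional assay on A-431 cells (Homo sapiens) for cytotoxicity, read by MTT assay, with a stated time of 24 h (on this read-out higher numbers stand for weaker inhibition and lower numbers for stronger inhibition), compound 1 (`COc1ccc(/C=C\C(=O)O)c(OCc2cn(-c3ccc(NC(=O)c4ccccc4)cc3)nn2)c1CC=C(C)C`) gives 21200 nM, compound 2 (`COc1ccc(/C=C\C(=O)O)c(OCc2cn(-c3cccc(C#N)c3)nn2)c1CC=C(C)C`) gives 22900 nM and compound 3 (`COc1ccc(/C=C\C(=O)O)c(OCc2cn(-c3ccccc3C(=O)N3CCC(O)C3)nn2)c1CC=C(C)C`) gives 31500 nM. The numbers do not separate compound 2 from compound 1 or compound 3, since both gaps lie within the scatter.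

Compound 4 (`COc1ccc(/C=C\C(=O)O)c(OCc2cn(-c3cccnc3Cl)nn2)c1CC=C(C)C`) is the next compound to be read. It carries 2-chloropyridin-3-yl in place of 3-cyanophenyl on an aromatic nitrogen of a five-membered aromatic ring with 3 nitrogen: 2-chloropyridin-3-yl in place of 3-cyanophenyl on an aromatic nitrogen.

Among the measured compounds shown here, no measured pair differs in one place only, so this change cannot be sized from a direct precedent. For the measured compounds named here, the only guide is that compound 1 at 21200 nM and compound 3 at 31500 nM, with quite different groups on that nitrogen, both stay within the scatter of compound 2. No step beyond the scatter is therefore expected in this assay, and no direction is favoured.

The expected step is a 1.1-fold higher number from compound 2 to compound 4 (0.04 log units; within the scatter), which is an estimate within the scatter. The estimated value for compound 4 is 25000 nM, with an expected range of 12000 nM to 50000 nM.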

Compound 4, half-maximal inhibitory concentration: 32600 nM
Compound 4: middle estimate off by 1.3-fold (0.12 log units), on the low side; the measured number falls inside the stated range.
By their numbers in this assay, from the lowest: compounds 1, 2, 3 and 4 (each within the scatter of the next).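

Among the compounds shown here, the first step that can be read replaces 3-cyanophenyl with 2-chloropyridin-3-yl on an aromatic nitrogen: in this assay it is a 1.4-fold higher number from compound 2 to compound 4 (0.15 log units; within the scatter). This exchange removes the nitrile and brings in a ring nitrogen and a chlorine, yet it does not separate the two compounds on this read-out. No measurement in hand bears on the reason for this result.

The nitrile, the ring nitrogen and the chlorine change together here, so the contribution of each remains unresolved. Also open, from the compounds shown here alone, is whether a different kind of group on that nitrogen, such as an aminoalkyl chain or a phenyl ring carrying a carboxylic acid, would give a step beyond the scatter, and what changes to the shared core would do.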